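A few compounds are considered here, and "the series" means these few. Any claim that something is new, unique, unknown or untested is made for them only; others in the source may bear on it.

Working notes on the series, read in an in vitro assay on HEK385-7 cells for displacement of a labelled ligand from prostaglandin D2 receptor 2 (Homo sapiens); on this read-out lower numbers stand for stronger inhibition and higher numbers for weaker inhibition.

Of the compounds shown here, two have been measured. Compound 1 `O=C(O)Cc1sc(Cc2ccccc2-c2ccccc2)nc1-c1ccc(Cl)cc1` gives 41 nM in this assay. Compound 2 `O=C(O)Cc1sc(C(c2ccc(F)cc2)c2ccc(F)cc2)nc1-c1ccc(Cl)cc1` gives 9.7 nM in this assay. Compound 2 therefore stands lowest of the two numbers, and its nearest neighbour is compound 1, whose number lies beyond the usual scatter above it. For the measured compounds named here, no pair of the measured compounds differs in only one place, so no single-change step can be read from them.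

The next compound, compound 3 `O=C(O)Cc1sc(C(c2ccc(F)cc2)c2ccc(F)cc2)nc1-c1ccnc(O)c1`, keeps the carboxymethyl-bearing core and the diarylmethyl group of compound 2 and changes one ring: 2-hydroxypyridin-4-yl in place of 4-chlorophenyl on an aromatic carbon

Going by the values given here, no measured pair shows what such a change does here, so the expectation rests on compound 2 alone. The step from the measured compound 2 to the new compound is estimated to run upward in number, that is toward weaker inhibition, a 4.1-fold higher number from compound 2 to compound 3 (0.62 log units; beyond the scatter), by an amount somewhat beyond the scatter but without a sign reversal in rank against compound 1. Compound 3 is expected to give about 40 nM in this assay, within a range from 10 nM to 160 nM.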

Compound 3, half-maximal inhibitory concentration: 68 nM
Beside the measured number, compound 3's estimate is 1.7-fold (0.23 log units) below it; measured number inside the range.
By their numbers in this assay, from the lowest: compound 2; then compounds 1 and 3 (each within the scatter of the next).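

For the compounds shown here, this is the first single-change step: in this assay, 2-hydroxypyridin-4-yl in place of 4-chlorophenyl, on the aromatic carbon next to the ring nitrogen and next to the ring atom that bears a carboxymethyl group, gives a 7.0-fold higher number from compound 2 to compound 3 (0.85 log units; beyond the scatter). The position therefore responds to the identity of this ring even at an unchanged heavy-atom count, when a ring of carbon only, without hydrogen-bond donors or acceptors, gives way to one with 1 hetero atom, 1 hydrogen-bond donor and 2 hydrogen-bond acceptors. No measurement is available that would tie this step to any one of those differences.

The compounds shown leave open whether the ring nitrogen, the hydroxyl group or the removal of the chlorine accounts for the step, and rings such as 4-hydroxyphenyl, pyridin-4-yl or 2-methoxypyridin-4-yl at this position would separate these changes. They also leave open whether the same exchange gives a step of similar size when the diarylmethyl group of compound 2 is replaced by the group that compound 1 carries on the shared core.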